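Cyano in place of 2-hydroxyethyl: clearance notes

This account rests on a few compounds, and the source may have more. Where it says the series, first, only, none or still open, it means among the compounds named here.

In an ADME assay on microsomes (Mus musculus) for metabolic stability (a lower number here means slower removal, a higher number faster removal of the compound), compound 1 `Cc1cc(C(F)(F)F)c2cccc(OCc3c(Cl)ccc(S(=O)(=O)N4CC[C@@H](N(C)C)C4)c3Cl)c2n1` gives 867 mL/min/kg and compound 2 `Cc1cc(C(F)(F)F)c2cccc(OCc3c(Cl)ccc(S(=O)(=O)N4CCC(CCO)CC4)c3Cl)c2n1` gives 1080 mL/min/kg. Within the data shown here, these two numbers lie within the scatter of each other, so compound 2 stands level with the only other measured compound. Compound 3 `Cc1cc(C(F)(F)F)c2cccc(OCc3c(Cl)ccc(S(=O)(=O)N4CCC(C#N)CC4)c3Cl)c2n1` carries cyano in place of 2-hydroxyethyl on a saturated ring carbon. Among the measured compounds shown here, no measured step covers this exact exchange. For the measured compounds named here, the one step that bears on it is a 1.2-fold higher number from compound 1 to compound 2 (0.10 log units; within the scatter), where 4-(2-hydroxyethyl)piperidin-1-yl replaces 3-(dimethylamino)pyrrolidin-1-yl on a sulfonyl sulfur. Going by the values given here, with only that step as a guide, no change beyond the scatter is expected in this assay. The estimated step is a 1.3-fold lower number from compound 2 to compound 3 (0.10 log units; within the scatter). Compound 3 is expected at 850 mL/min/kg, with an estimated range of 430 mL/min/kg to 1400 mL/min/kg.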

Compound 3, clearance: 1720 mL/min/kg
Compound 3: middle estimate off by 2.0-fold (0.31 log units), on the low side; the measured number lies above the stated range.
By their numbers in this assay, from the lowest: compounds 1, 2 and 3 (each within the scatter of the next).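

In this assay, the exchange on the saturated ring carbon gives a 1.6-fold higher number from compound 2 to compound 3 (0.20 log units; within the scatter), so at this place a cyano group, which carries no hydrogen-bond donor, and a 2-hydroxyethyl group, which carries one, cannot be told apart by clearance. The wider exchange on the sulfonyl sulfur reads the same way, with a 2.0-fold higher number from compound 1 to compound 3 (0.30 log units; within the scatter) for 4-cyanopiperidin-1-yl in place of 3-(dimethylamino)pyrrolidin-1-yl, so none of the three groups shown separates from the others beyond the scatter. Nothing at hand bears on what sets these clearance numbers.

Going by these compounds, whether a carboxylic acid, a primary amine or a longer chain such as 3-hydroxypropyl on the same ring carbon would move clearance beyond the scatter remains open. Also open, on these data alone, is whether a change in the shared core would do so where these changes on the six-membered ring do not.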